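The source may hold more compounds than are shown below. What is called first, only, known or untested is meant among the compounds shown, and "the series" means these compounds.

Measured compounds in an ADME assay on NCM460 cells (Homo sapiens) for cytotoxicity, read by MTT assay, with a stated time of 72 h, in the presence of a further agent that is not named here; on this read-out higher numbers stand for an effect only at larger amounts of compound and lower numbers for an effect already at smaller amounts:
compound 1 `CNc1cc(C)nc(NNC(=O)Nc2cc(Cl)nc(Cl)c2)n1` gives 65300 nM
compound 2 `Cc1cc(NC(=O)Nc2cc(Cl)nc(Cl)c2)cc(C)n1` gives 576000 nM
compound 3 `O=C(Nc1cc(Cl)nc(Cl)c1)Nc1cc(Cl)nc(Cl)c1` gives 9440 nM

Compound 3 stands at the lowest of the three numbers in this assay; compound 1 sits higher, beyond the scatter, and compound 2 higher still, also beyond the scatter. No two of these compounds differ in one place only, so no single measured step is available in this series.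

Compound 4 `O=C(Nc1cc(Cl)nc(Cl)c1)Nc1cc(Cl)nc(OC2CCCC2)c1` follows from compound 3 by cyclopentyloxy in place of chloro on an aromatic carbon. The three numbers give no direct reading of such a change. For compound 4 the expected value in this assay is 15000 nM, with a range of 4000 nM to 55000 nM. The step expected is a 1.6-fold higher number from compound 3 to compound 4 (0.20 log units; within the scatter), modest and in no direction clearly beyond the scatter.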

Compound 4, half-maximal effective concentration: 21400 nM
The estimate for compound 4 lay 1.4-fold (0.15 log units) below the measured number; low and high end bracket the measured number.
By their numbers in this assay, from the lowest: compound 3; then compound 4; then compound 1; then compound 2.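

In this assay, the series gains its first step in one place, on an aromatic carbon next to the ring nitrogen: cyclopentyloxy in place of chloro gives a 2.3-fold higher number from compound 3 to compound 4 (0.36 log units; beyond the scatter). This position therefore takes a group of several more heavy atoms, including a non-aromatic ring, with a modest but real rise in the number. Nothing measured here accounts for that rise.

On these data alone, whether methoxy, a longer alkoxy chain or an amine at this position would give a similar number remains open. So does the effect of replacing the remaining chloro groups.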